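Replacing the aminophenyl group of compound 3

A few compounds are considered here, and "the series" means these few. Any claim that something is new, unique, unknown or untested is made for them only; others in the source may bear on it.

Measured in a functional assay on K562 cells (Homo sapiens) for cytotoxicity, read by trypan blue exclusion, with a stated time of 96 h; on this read-out higher numbers stand for weaker inhibition and lower numbers for stronger inhibition:
- compound 1 `COc1ccc(N)cc1CS(=O)(=O)/C=C/c1c(OC)cccc1OC`: 25000 nM
- compound 2 `COc1cc(OC)c(/C=C/S(=O)(=O)Cc2ccc(OC)c(N)c2)c(OC)c1`: 2.5 nM
- compound 3 `COc1cc(OC)c(/C=C/S(=O)(=O)Cc2cc(N)ccc2OC)c(OC)c1`: 7500 nM

Compound 3 holds the middle of the three numbers, far above compound 2 and closer to compound 1. Compound 4 `COc1cc(OC)c(/C=C/S(=O)(=O)Cc2ccc(Cl)cc2N)c(OC)c1` carries 2-amino-4-chlorophenyl in place of 5-amino-2-methoxyphenyl on a saturated chain carbon bound to a sulfonyl sulfur. A change at this same place gave a large step (a 3000-fold higher number from compound 2 to compound 3 (3.48 log units; beyond the scatter)), so wide movement is possible. Methoxy in place of hydrogen on an aromatic carbon gave a modest one (a 3.3-fold lower number from compound 1 to compound 3 (0.52 log units; beyond the scatter)). Among the measured compounds shown here, no measured compound carries chlorine, so no direction is firm. The expected step is small (a 1.5-fold lower number from compound 3 to compound 4 (0.18 log units; within the scatter)). For compound 4 the estimated value is 5000 nM (expected range 500 nM to 30000 nM).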

Compound 4, half-maximal inhibitory concentration: 2500 nM
Compound 4: the middle estimate sits 2.0-fold (0.30 log units) above what was measured, and the stated range covers the measured number.
By their numbers in this assay, from the lowest: compound 2; then compound 4; then compound 3; then compound 1.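

In this assay, among the compounds shown here, a chlorine-bearing ring on the saturated chain carbon bound to the sulfonyl sulfur gives a 3.0-fold lower number from compound 3 to compound 4 (0.48 log units; beyond the scatter), so 5-amino-2-methoxyphenyl is not the only aminophenyl group that can be changed here with a modest shift. Set against the best compound, 2-amino-4-chlorophenyl still gives a 1000-fold higher number from compound 2 to compound 4 (3.00 log units; beyond the scatter), and among the groups at this place only 3-amino-4-methoxyphenyl reaches the low end of the range. No measurement shown explains these differences.

Open, from the compounds shown here alone, is whether the low number of compound 2 survives a hydroxyl or an amide in place of its amine.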